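The source may hold more compounds than are shown below. What is called first, only, known or untested is meant among the compounds shown, and "the series" means these compounds.

Measured so far:
compound 1 `COc1ccc(F)cc1CNCCCNc1ccnc2cc(C3CCCCC3)ccc12`: 2290 nM
compound 2 `Fc1ccc(-c2ccc3c(NCCCNCc4ccco4)ccnc3c2)cc1`: 7760 nM
compound 3 `COc1ccc(Oc2ccc3c(NCCCNCc4cccc(OC)c4O)ccnc3c2)cc1`: 5500 nM

In an ADME assay on HepG2 cells (Homo sapiens) for cytotoxicity, read by luminescence, CellTiter-Glo and ATP content, with a stated time of 72 h (a lower number here means that less compound is needed, a higher number that more compound is needed for the effect), compound 1 gives the lowest of the three numbers. Compound 3 stands nearest, a gap beyond the scatter, and compound 2 stands furthest, also beyond the scatter. Compound 4 `COc1ccc(F)cc1CNCCCNc1ccnc2cc(Oc3ccc(C(C)(C)C)cc3)ccc12` differs from compound 1 in one place: 4-(tert-butyl)phenoxy in place of cyclohexyl on an aromatic carbon. Among the compounds with values here, no step between measured compounds isolates such an exchange, so the expectation rests on the whole set. Compound 3, which also carries a phenoxy group on its core, gives 5500 nM, a higher number than compound 1. The step from compound 1 to compound 4 is expected to be small, a 1.2-fold higher number from compound 1 to compound 4 (0.09 log units; within the scatter), within the usual scatter. Compound 4 is estimated at 2800 nM, between 1100 nM and 7000 nM.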

Compound 4, half-maximal effective concentration: 7200 nM
Beside the measured number, compound 4's estimate is 2.6-fold (0.41 log units) below it; the whole stated range lies below it.
By their numbers in this assay, from the lowest: compound 1; then compounds 3, 4 and 2 (each within the scatter of the next).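

In this assay the exchange of cyclohexyl for 4-(tert-butyl)phenoxy on this aromatic carbon gives a 3.1-fold higher number from compound 1 to compound 4 (0.50 log units; beyond the scatter), the first sign from a single-place change that the number responds to the group held here. The exchange alters the ring, the size of the group and the oxygen together, so this one step cannot separate them. No evidence on the cause of the step is available. The compounds shown leave open whether plain phenoxy, a methoxy group or an amine at this place would stand nearer compound 1 or compound 4.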